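Hydrazone series: hydroxy-ring substitution, compound 3 to compound 4

A few compounds are considered here, and "the series" means these few. Any claim that something is new, unique, unknown or untested is made for them only; others in the source may bear on it.

Measured so far in a functional assay on OVCAR-8 cells (Homo sapiens) for inhibition, read by MTT assay; on this read-out lower numbers stand for stronger inhibition and higher numbers for weaker inhibition:
compound 1 `O=[N+]([O-])c1ccc(O)c(/C=N/Nc2cnc3ccccc3n2)c1` gives 2840 nM
compound 2 `Clc1cccc(/C=N/Nc2cnc3ccccc3n2)c1Cl` gives 6190 nM
compound 3 `Oc1ccccc1/C=N/Nc1cnc2ccccc2n1` gives 3470 nM

Compound 3 has the second highest of the three numbers; its nearest neighbour is compound 1 and its furthest is compound 2, and both gaps lie within the scatter. Within the data shown here, the only step between two measured compounds that differ in one place is a 1.2-fold higher number from compound 1 to compound 3 (0.09 log units; within the scatter), a change on the same ring as the hydroxy group that left the number essentially where it was.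

Compound 4 `COc1ccc(/C=N/Nc2cnc3ccccc3n2)c(O)c1` differs from compound 3 by methoxy in place of hydrogen on an aromatic carbon. Among the measured compounds shown here, the one comparable step bears on it directly and was within the scatter, so no step beyond the scatter is expected in this assay for compound 4, in either direction. The expected step is a 1.0-fold higher number from compound 3 to compound 4 (0.00 log units; within the scatter). For compound 4 the estimate is 3500 nM, with a range from 1500 nM to 8000 nM.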

Compound 4, half-maximal inhibitory concentration: 7550 nM
Compound 4: middle estimate off by 2.2-fold (0.33 log units), on the low side, within the range that was stated.
By their numbers in this assay, from the lowest: compounds 1, 3, 2 and 4 (each within the scatter of the next, the first and the last beyond it).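

In this assay, among these compounds, methoxy on the aromatic carbon meta to the hydroxy group and para to a large group gives a 2.2-fold higher number from compound 3 to compound 4 (0.34 log units; beyond the scatter), the first single-place change to pass beyond the scatter, and it moves toward weaker inhibition. The position therefore responds to substitution, although the step is modest and rests on this one pair. Nothing available accounts for the step.

Going by these compounds, whether the shift belongs to methoxy itself or to any group at this carbon remains open. Fluorine, an amine or a longer ethoxy chain there would separate those readings.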